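Saturated hexyl chain in place of the phenylbutynyl arm

The source may hold more compounds than are shown below. What is called first, only, known or untested is meant among the compounds shown, and "the series" means these compounds.

Compound 3 `CC(=O)Nc1nc(-c2cccc(NS(=O)(=O)c3ccc(C#CCCc4ccccc4)cc3)c2)cs1` gives 4.2% in a functional assay on A-375 cells (Homo sapiens) for antiproliferative activity, read by trypan blue exclusion, with a stated time of 48 h, tested at 5 uM (a higher number here means a weaker effect of the compound at the concentration tested, a lower number a stronger effect), the lowest of the three numbers; compound 1 `CCCCCCC#Cc1ccc(S(=O)(=O)Nc2cccc(-c3csc(NC(C)=O)n3)c2)cc1` stands nearest with 12.8%, a gap within the scatter, while compound 2 `CC(=O)Nc1nc(-c2cccc(NS(=O)(=O)c3ccc(C#CCO)cc3)c2)cs1` lies furthest with 99.3%, beyond the scatter. Compound 4 `CCCCCCc1ccc(S(=O)(=O)Nc2cccc(-c3csc(NC(C)=O)n3)c2)cc1` differs from compound 3 by hexyl in place of 4-phenylbut-1-yn-1-yl on an aromatic carbon. Among the compounds with values here, two measured steps bear on this: a number 8.6 percentage points lower from compound 1 to compound 3 (within the scatter) shows little change for phenyl in place of butyl, whereas a number 86.5 percentage points higher from compound 1 to compound 2 (beyond the scatter) shows a large rise for hydroxy in place of pentyl. Within the data shown here, compound 4 carries a plain hexyl chain, and a number near that of compound 1, 12.8%, is expected; no measured step covers loss of the triple bond, so the range is wide. Compound 4 is expected at 20% (5% to 55%), a step of a number 15.8 percentage points higher from compound 3 to compound 4 (beyond the scatter).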

Compound 4, a percentage reported as activity, at one concentration (the size of the read-out at that concentration, not a potency): < 1%
Compound 4: a limit, no number (the forecaster's own chance of this, stated with the estimate: 0%); middle value at least 19 percentage points away from the limit.
By their numbers in this assay, from the lowest: compounds 3 and 1 (each within the scatter of the next); then compound 2. At a limit, below all of these: compound 4.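

In this assay compound 4 gives < 1%, which is a limit of the assay and not a number. At this position, neither the triple bond nor a ring is required for the effect at the concentration tested, since a plain hexyl chain gives a number at least 11.8 percentage points lower from compound 1 to compound 4 (beyond the scatter) and a number at least 98.3 percentage points lower from compound 2 to compound 4 (beyond the scatter). Against the phenyl-bearing arm, the change gives a number at least 3.2 percentage points lower from compound 3 to compound 4 (that floor lies within the scatter).

From the compounds shown here alone, whether a shorter or longer saturated chain, or a hexyl chain ending in an amine or a carboxylic acid, keeps this effect remains open. Also open, going by these compounds, is whether the weak reading of compound 2 follows from its hydroxy group or its short chain.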